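An Amino Group Added to Compound 2

A few compounds are considered here, and "the series" means these few. Any claim that something is new, unique, unknown or untested is made for them only; others in the source may bear on it.

In a physicochemical assay for solubility, read by LC-MS, in phosphate buffer, with a stated time of 24 h, at pH 6.8 (on this read-out lower numbers stand for lower solubility and higher numbers for higher solubility), compound 1 (`C[C@H](NC(=O)c1cccc(F)c1)c1ccc(NC(=O)N2CC(c3cccnc3)C2)cc1`) gives 11000 nM, compound 3 (`C[C@H](NC(=O)C1CCOCC1)c1ccc(NC(=O)N2CC(c3cccnc3)C2)cc1`) gives 380000 nM, and compound 2 (`C[C@H](NC(=O)c1ncccn1)c1ccc(NC(=O)N2CC(c3cccnc3)C2)cc1`) gives 930000 nM, the highest of the three. Compound 4 (`C[C@H](NC(=O)c1ncccn1)c1ccc(NC(=O)N2CC(c3cncc(N)c3)C2)cc1`) keeps the pyrimidin-2-yl of compound 2 but carries amino in place of hydrogen on an aromatic carbon, turning pyridin-3-yl into 5-aminopyridin-3-yl: amino in place of hydrogen on an aromatic carbon. The measured steps all replace a group on a carbonyl carbon, and none tests this place. Two are large, an 85-fold higher number from compound 1 to compound 2 (1.93 log units; beyond the scatter) and a 35-fold higher number from compound 1 to compound 3 (1.54 log units; beyond the scatter), and the closest size guide is the modest 2.4-fold lower number from compound 2 to compound 3 (0.39 log units; beyond the scatter). A modest downward step is therefore expected, a 2.3-fold lower number from compound 2 to compound 4 (0.37 log units; beyond the scatter). For compound 4 the estimated value is 400000 nM, with an expected range of 130000 nM to 1200000 nM.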

Compound 4, solubility: 300000 nM
Compound 4: the middle estimate sits 1.3-fold (0.12 log units) above what was measured; measured number inside the range.
By their numbers in this assay, from the lowest: compound 1; then compounds 4 and 3 (each within the scatter of the next); then compound 2.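

Among the compounds shown here, on the pyridin-3-yl, a place the earlier steps left untouched, amino in place of hydrogen gives a 3.1-fold lower number from compound 2 to compound 4 (0.49 log units; beyond the scatter) in this assay. This step is beyond the scatter but far smaller than an 85-fold higher number from compound 1 to compound 2 (1.93 log units; beyond the scatter), made on the carbonyl carbon. Nothing measured here explains the step. As far as these compounds go, whether hydroxyl or methoxy on the same aromatic carbon would give a step of similar size remains open. So does whether amino would give the same step with oxan-4-yl in place of pyrimidin-2-yl on the carbonyl carbon.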